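The source may report more compounds than this note shows. Statements on the series, on what has been measured and on what is new or still open speak of the compounds shown alone.

Among the measured compounds shown here, in a functional assay on MCF7 cells (Homo sapiens) for inhibition, read by MTT assay, with stated times of 18 h and 4 h (on this read-out higher numbers stand for weaker inhibition and lower numbers for stronger inhibition), compound 3 `CCCOP(=O)(O)OCCSC(=S)N1CCCC1` gives 73000 nM, the only true number in this small set. Compound 1 `CCCOP(=O)(O)OCCSC(=S)N1CCCCC1` reads > 100000 nM, which is a limit of the assay. Compound 2 `CCCCCCCCCCCCCCCCOP(=O)(O)OCCSC(=S)N1CCN(C)CC1` reads > 100000 nM, which is also a limit.

Compound 4 `CCCCCCOP(=O)(O)OCCSC(=S)N1CCCC1` keeps the pyrrolidin-1-yl group of compound 3 and changes the chain: propyl in place of hydrogen on a saturated chain carbon, three bonds along the chain from an oxygen on an unsaturated carbon. Put another way, propyl becomes hexyl. For the measured compounds named here, the one measured step, an at least 1.3-fold lower number from compound 1 to compound 3 (0.13 log units; that floor lies within the scatter), concerns pyrrolidin-1-yl in place of piperidin-1-yl on a thiocarbonyl carbon, and its floor lies within the scatter. It therefore says nothing about the chain. Compound 2 has a longer chain than compound 4 but also differs at the other end, so it offers no clean comparison.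

With so little guidance, only a modest move toward a lower number is expected in this assay. The estimated change is a 1.5-fold lower number from compound 3 to compound 4 (0.16 log units; within the scatter). For compound 4 the expected value is 50000 nM, with an estimated range of 18000 nM to 100000 nM.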

Compound 4, half-maximal inhibitory concentration: 100000 nM
Compound 4: middle estimate off by 2.0-fold (0.30 log units), on the low side; low and high end bracket the measured number.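

In this assay, the change from propyl to hexyl with the pyrrolidin-1-yl group held constant gives a 1.4-fold higher number from compound 3 to compound 4 (0.14 log units; within the scatter), so the two compounds cannot be told apart on this read-out. Among the compounds shown here, this is the first clean reading of the chain at this position, which the earlier step at the thiocarbonyl carbon could not give, and across this change it shows no separation. The number for compound 4 also stands at the same figure as the limit reached elsewhere in this set, which leaves little room to read any weaker inhibition: the limit of > 100000 nM in this assay, at which 2 of the 4 values shown sit.

On these data alone, whether a longer chain on the same pyrrolidin-1-yl compound, or a chain ending in an amine or a carboxylic acid, would read differently stays open. Also open, as far as these compounds go, is whether a chain shorter than propyl, such as ethyl, would give a number apart from compound 3.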